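Chain shortening on two pyrazine amide cores and cytotoxicity

This account rests on a few compounds, and the source may have more. Where it says the series, first, only, none or still open, it means among the compounds named here.

The study compares four compounds in an ADME assay on MDCK cells (Canis lupus familiaris) for cytotoxicity, read by microscopy, with a stated time of 6 days; a lower number here means that less compound is tolerated, a higher number that more compound is tolerated. Compound 1 `CCCCCCNc1cncc(C(=O)NCc2ccccc2)n1` gives 20000 nM in this assay, the lowest of the two plain numbers. Compound 2 `CCCCCCCNc1nccnc1C(=O)NCc1ccccc1` gives 100000 nM in this assay, a value standing above that of compound 1 by a gap that lies beyond the usual scatter. Compound 3 `CCCCCNc1nccnc1C(=O)NCc1ccccc1` gives only a limit of the assay, >= 20000 nM, and not a number. The difference between the cores of compound 1 and compound 2 is not broken down here.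

From compound 2 to compound 3 the change is hydrogen in place of ethyl on a saturated chain carbon, five bonds along the chain from a nitrogen on an aromatic ring. The step that the limit leaves unreadable from compound 2 to compound 3 cannot be read because of the limit of >= 20000 nM in this assay, at which 1 of the 3 values shown sits.

Compound 4 `CCCCNc1cncc(C(=O)NCc2ccccc2)n1` is not yet measured. It differs from compound 1 by hydrogen in place of ethyl on a saturated chain carbon, four bonds along the chain from a nitrogen on an aromatic ring. Going by the values given here, this is the same kind of change as the one from compound 2 to compound 3, though the place is not the same: there the carbon sits five bonds along the chain from the nitrogen on the aromatic ring, here four bonds along it.

Among the compounds with values here, since the only measured instance of this kind of change gives no readable size, the expectation for compound 4 rests mainly on the value of compound 1, 20000 nM, and on the spread seen between compound 1 and compound 2. Compound 4 is expected to show a step of a 2.0-fold higher number from compound 1 to compound 4 (0.30 log units; within the scatter) in this assay. The estimate for compound 4 is therefore 40000 nM, with a range expected from 15000 nM to 100000 nM.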

Compound 4, minimum cytotoxic concentration: 100000 nM
Estimate against measurement, compound 4: 2.5-fold (0.40 log units) below, within the range that was stated.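

On the core of compound 1, hydrogen in place of ethyl on a saturated chain carbon, four bonds along the chain from a nitrogen on an aromatic ring, gives a 5.0-fold higher number from compound 1 to compound 4 (0.70 log units; beyond the scatter) in this assay, so on this core the compound with the shorter chain is tolerated at a higher concentration. Whether this carries over to the other core cannot be said, since the matching change there sits five bonds along the chain and not four, and its step cannot be read because compound 3 gives a limit and not a number: the limit of >= 20000 nM in this assay, at which 1 of the 4 values shown sits. The series therefore offers one readable instance of this change, on one core, which shows its size there but establishes no rule that holds from one core to another.

The compounds shown leave open how the number would move along a run of chains on either core, for instance with a propyl chain or with a chain longer than those present. They also leave open what a chain ending in a carboxylic acid or an amine would do in this assay, and how much of any such result would belong to the core and how much to the chain.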